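The source may report more compounds than this note shows. Statements on the series, on what has been measured and on what is new or still open speak of the compounds shown alone.

In an in vitro ADME assay on microsomes from liver (Homo sapiens) for pharmacokinetics, read by LC-MS (on this read-out lower numbers stand for slow clearance and higher numbers for fast clearance), compound 1 (`Cc1ccc2c(c1)nc(C)n2-c1ccc(C(=O)NC2CC2)s1`) gives 8 mL/min/kg and compound 2 (`Cc1ccc2nc(C)n(-c3ccc(C(=O)NC4CC4)s3)c2c1`) gives 10 mL/min/kg. These two numbers lie within the usual scatter of each other, so the measurements do not separate compound 2 from compound 1. Within the data shown here, compound 3 (`Cc1nc2c(F)cccc2n1-c1ccc(C(=O)NC2CC2)s1`), the one measured compound carrying fluoro, gives < 4 mL/min/kg, and this is a limit of the assay, not a number.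

Compound 4 (`Cc1nc2ccc(F)cc2n1-c1ccc(C(=O)NC2CC2)s1`) departs from compound 2 at one place: fluoro in place of methyl on an aromatic carbon. Among the measured compounds shown here, no measured pair isolates this change, so the size of the step cannot be read directly from the data. The limit reached by compound 3 gives only a weak lean towards a lower number in this assay, towards slow clearance. The estimated step, a 1.7-fold lower number from compound 2 to compound 4 (0.22 log units; within the scatter), is therefore modest and is not expected to go beyond the scatter. For compound 4 the expected clearance is 6 mL/min/kg, with an estimated range of 4 mL/min/kg to 11 mL/min/kg.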

Compound 4, clearance: < 4 mL/min/kg
Compound 4: a limit, no number (the forecaster's own chance of this, stated with the estimate: 25%); middle value at least 1.5-fold (0.17 log units) from the limit.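

In this assay, among these compounds, fluoro in place of methyl on an aromatic carbon, meta to a fused ring and para to a fused ring, gives an at least 2.5-fold lower number from compound 2 to compound 4 (0.39 log units; beyond the scatter); this is the first pair to isolate this change, and it puts the drop in clearance beyond the scatter. Compound 4 gives < 4 mL/min/kg, which is a limit of the assay and not a number. The full size of the step therefore cannot be read, only its minimum: the limit of < 4 mL/min/kg in this assay, at which 2 of the 4 values shown sit.

From the compounds shown here alone, how a group other than fluoro at this position, such as chloro, a nitrile or an amine, would read in this assay stays open. Compound 3 and compound 4 both stand at limits, so no order between them can be read.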